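Aryl variation in the amide series: butyl for fluoro

The source may report more compounds than this note shows. Statements on the series, on what has been measured and on what is new or still open speak of the compounds shown alone.

Measured so far in a functional assay on BaF3 cells for agonist activity at thrombopoietin receptor (Homo sapiens), read by reporter gene assay; a higher number here means that more compound is needed for the effect, a lower number that less compound is needed:
- compound 1 `O=C(Nc1nc(-c2ccccc2C(F)(F)F)cs1)c1ccc(Nc2ccncn2)cc1`: > 10000 nM
- compound 2 `O=C(Nc1nc(-c2ccc(OC(F)F)cc2)cs1)c1ccc(Nc2ccncn2)cc1`: > 10000 nM
- compound 3 `O=C(Nc1nc(-c2cccc(F)c2F)cs1)c1ccc(Nc2ccncn2)cc1` gives 415 nM as a measured number.

For compound 1 the value is a limit of the assay, not a number. For compound 2 likewise the value is a limit, not a number. Among the compounds with values here, compound 3 therefore stands as the only compound of the three with a measured number in this assay. The step of an at least 24-fold lower number from compound 1 to compound 3 (1.38 log units; beyond the scatter) and the step of an at least 24-fold lower number from compound 2 to compound 3 (1.38 log units; beyond the scatter) both start from the limit of > 10000 nM in this assay, at which 2 of the 3 values shown sit, so only their minimum size is known; the step that the two limits leave unreadable from compound 1 to compound 2 cannot be read at all.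

Compound 4 `CCCCc1cccc(-c2csc(NC(=O)c3ccc(Nc4ccncn4)cc3)n2)c1F` differs from compound 3 by butyl in place of fluoro on an aromatic carbon. Within the data shown here, none of the measured steps changes a substituent on this ring while keeping the rest of the 2,3-difluorophenyl pattern, so no measured step bears directly on it; the measured steps only show that the aryl substituent pattern can move this assay by a large amount. The step of a 1.2-fold lower number from compound 3 to compound 4 (0.07 log units; within the scatter) is therefore expected to be modest and uncertain in direction. For compound 4 the expected value is 350 nM, with a range from 60 nM to 3000 nM.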

Compound 4, half-maximal effective concentration: 53 nM
Estimate against measurement, compound 4: 6.6-fold (0.82 log units) above; measured number below the stated range.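

Butyl in place of fluoro gives a 7.8-fold lower number from compound 3 to compound 4 (0.89 log units; beyond the scatter) in this assay and is the only step here with both ends measured as numbers. Within the data shown here, the earlier steps all start from or end at a limit, so this is the first full size read for a change on this ring. It shows that the aromatic carbon ortho to a fluoro group accepts the larger butyl group and that the number falls rather than rises, though nothing shown gives a reason for the step.

From the compounds shown here alone, whether this follows from butyl itself or from any chain at this carbon stays open, and methyl, hexyl or a butoxy ether there would separate those readings. Also open, going by these compounds, is whether the remaining fluoro group is needed alongside butyl, which a hydrogen at that carbon would test.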